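Hydroxy to acetoxy on two cores

The source may hold more compounds than are shown below. What is called first, only, known or untested is meant among the compounds shown, and "the series" means these compounds.

Measured so far:
compound 1 `CC[C@@H]1O[C@H](COCc2ccccc2)[C@@H](OCc2ccccc2)[C@H](OCc2ccccc2)[C@H]1O` — 19800 nM
compound 2 `CC[C@@H]1O[C@H](COCc2ccccc2)[C@@H](OCc2ccccc2)[C@H](OCc2ccccc2)[C@H]1OC(C)=O` — > 50000 nM
compound 3 `CCC[C@@H]1O[C@H](COCc2ccc3ccccc3c2)[C@@H](OCc2ccc3ccccc3c2)[C@H](OCc2ccc3ccccc3c2)[C@H]1O` — > 50000 nM

In a functional assay on HeLa cells (Homo sapiens) for antiproliferative activity, read by sulforhodamine B assay (on this read-out lower numbers stand for stronger inhibition of growth and higher numbers for weaker inhibition of growth), compound 1 gives 19800 nM. Compound 2 reaches only a limit of the assay, > 50000 nM. The step of an at least 2.5-fold higher number from compound 1 to compound 2 (0.40 log units; beyond the scatter) corresponds to the change (acetyl in place of hydrogen on an oxygen on a saturated carbon). Compound 3 also reaches only a limit of the assay, > 50000 nM. Note (the limit of > 50000 nM in this assay, at which 2 of the 3 values shown sit). The difference between the core of compound 1 and the core of compound 3 is not broken down here.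

Compound 4 `CCC[C@@H]1O[C@H](COCc2ccc3ccccc3c2)[C@@H](OCc2ccc3ccccc3c2)[C@H](OCc2ccc3ccccc3c2)[C@H]1OC(C)=O` is not yet measured. It differs from compound 3 by acetyl in place of hydrogen on an oxygen on a saturated carbon, the same change as between compound 1 and compound 2, at the same place. For compound 4 the step that the limit leaves unreadable from compound 3 to compound 4 is expected. The expectation rests on compound 3 sitting at > 50000 nM. It further rests on the earlier change having given an at least 2.5-fold higher number from compound 1 to compound 2 (0.40 log units; beyond the scatter), a number moving in the weaker direction. Compound 4 is therefore estimated at 80000 nM, most likely reported again only as a limit, within a range from 40000 nM to 200000 nM.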

Compound 4, concentration for 50% growth inhibition: > 50000 nM
Compound 4: only a limit was reported (the forecaster's own chance of this, stated with the estimate: 85%); the middle value is on the limit's open side.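

Compound 3 and compound 4 both stand only as limits in this assay, so the hydroxy to acetoxy step on this core cannot be read: the limit of > 50000 nM in this assay, at which 3 of the 4 values shown sit. As far as these compounds go, what stays open is how far compound 3 and compound 4 lie past that limit, and whether hydroxy to acetoxy acts on the core of compound 3 as on the core of compound 1.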